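This account rests on a few compounds, and the source may have more. Where it says the series, first, only, none or still open, it means among the compounds named here.

Compound 1 `CSc1nc(NCCCCCO)c2ccccc2n1` shares its core with compound 3 `CSc1nc(Nc2ccccc2)c2ccccc2n1` and has a close relative in compound 2 `[SeH]c1nc(NCc2ccccc2)c2cccnc2n1`. In a functional assay on MCF7 cells (Homo sapiens) for cytotoxicity, read by MTT assay, with a stated time of 72 h (on this read-out higher numbers stand for weaker inhibition of growth and lower numbers for stronger inhibition of growth), compound 1 gives only a limit, > 100000 nM, not a number. Compound 3 likewise reaches only a limit, > 100000 nM. Compound 2 also stops at a limit, > 100000 nM. Within the data shown here, the one measured change, a step that the two limits leave unreadable from compound 1 to compound 3, cannot be sized because the limit of > 100000 nM in this assay, at which 3 of the 3 values shown sit, holds every value shown. Compound 4 `CSc1nc(NCCCCc2ccccc2)c2ccccc2n1` differs from compound 1 by phenyl in place of hydroxymethyl on a saturated chain carbon, four bonds along the chain from a nitrogen on an aromatic ring. No measured step reaches this change, so neither direction nor size can be drawn from the data shown. Compound 4 is therefore expected to sit near 100000 nM, within 30000 nM to 300000 nM. That estimate means an expected step of a number no higher from compound 1 to compound 4 (the limit leaves the size open), not beyond the scatter.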

Compound 4, concentration for total growth inhibition: 64000 nM
Compound 4: the middle estimate sits 1.6-fold (0.19 log units) above what was measured, within the range that was stated.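

With phenyl in place of hydroxymethyl on the chain, compound 4 is the first compound shown to give a number rather than a limit in this assay. Going by these compounds, the change reads as an at least 1.5-fold lower number from compound 1 to compound 4 (0.19 log units; that floor lies within the scatter), so its true size stays open. Most values still stop at a single limit: the limit of > 100000 nM in this assay, at which 3 of the 4 values shown sit.

On these data alone, it remains open whether the phenyl or the loss of the hydroxymethyl matters more. Also open, as far as these compounds go, is whether an amine or a carboxylic acid at this place, or a longer chain carrying the phenyl, would give a lower number.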